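Removing a Methoxy Group from a Trimethoxy Analogue

This account rests on a few compounds, and the source may have more. Where it says the series, first, only, none or still open, it means among the compounds named here.

Measured compounds:
compound 1 `Cc1ccc2c(c1)C(=O)/C(=C/c1ccccc1)CN2CC(=O)O` — 4.23%
compound 2 `COc1cccc(/C=C2\CN(CC(=O)O)c3ccc(C)cc3C2=O)c1` — 14.4%
compound 3 `COc1ccc(/C=C2\CN(CC(=O)O)c3c(C)cccc3C2=O)c(OC)c1OC` — 1.57%

In an assay on HL-60 cells for inhibition of glutathione S-transferase P (Homo sapiens), read by spectrophotometry, tested at 20 uM (a higher number here means more inhibition at the concentration tested (going by the name of the read-out), a lower number less inhibition), compound 2 gives 14.4%, and compound 1 gives 4.23%. The two differ only by hydrogen in place of methoxy on an aromatic carbon, a change that made a step of a number 10.2 percentage points lower from compound 2 to compound 1 (beyond the scatter). Compound 3, at 1.57%, has the lowest of the three numbers; its distance to compound 1 lies within the scatter, while its distance to compound 2 lies beyond it. The difference between the core of compound 3 and the core of compound 2 is not broken down here.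

Compound 4 `COc1ccc(/C=C2\CN(CC(=O)O)c3c(C)cccc3C2=O)c(OC)c1` has not yet been measured in this assay. It differs from compound 3 by hydrogen in place of methoxy on an aromatic carbon. Going by the values given here, this is the same kind of change as the one from compound 2 to compound 1, but the surroundings are not identical: in compound 3 the carbon that loses its methoxy is ortho to two methoxy groups and meta to a large group, whereas in compound 2 it is only meta to a large group. The earlier step went downward, but compound 3 already sits near the bottom of the range, so little room for a further drop remains. The step from compound 3 to compound 4 is therefore estimated at a number 0.4 percentage points higher from compound 3 to compound 4 (within the scatter), a near-zero change, because compound 3 gives 1.57%. For compound 4 the expected inhibition is 2%, with a likely range from -5% to 10%.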

Compound 4, a percentage reported as inhibition, at one concentration (the size of the read-out at that concentration, not a potency): 11.7%
Compound 4: the middle estimate sits 9.7 percentage points below what was measured; measured number above the stated range.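

In this assay, hydrogen in place of methoxy on an aromatic carbon gives a number 10.1 percentage points higher from compound 3 to compound 4 (beyond the scatter), and set beside the earlier case, the same change does not carry over from one core to the other with the same outcome: the same change on two cores in this assay, a number 10.2 percentage points lower (beyond the scatter) from compound 2 to compound 1 and a number 10.1 percentage points higher (beyond the scatter) from compound 3 to compound 4, 20.3 percentage points apart, beyond the scatter of two such steps. For this series, the result shows that the step seen on one core cannot be assumed to apply to the other, as the two steps are of similar size but run in opposite directions. Going by these compounds alone, it does not show what sets the direction, since only two pairs are available and they differ in more than one respect: the methoxy lost from compound 3 is ortho to two methoxy groups, the one lost from compound 2 is not, and the two cores also differ, so neither difference can be singled out as the one that matters.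

The compounds shown leave open whether the reversal would follow the remaining methoxy groups or the core if one of these were varied alone. They also leave open how a hydroxyl group or a chlorine atom would behave in place of the methoxy on either core.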